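From 3,4-dichlorophenyl to 2-bromophenyl: an expected loss

The source may hold more compounds than are shown below. What is called first, only, known or untested is meant among the compounds shown, and "the series" means these compounds.

Within the data shown here, in a functional assay on HCT-116 cells (Homo sapiens) for antiproliferative activity, read by MTT assay, with a stated time of 72 h (on this read-out lower numbers stand for stronger inhibition and higher numbers for weaker inhibition), compound 1 (`NC1=NC2(CCSCC2)N(OCCCOc2ccc(Cl)c(Cl)c2)C(N)=N1`) gives 1 nM and holds the lower of the two numbers so far. Compound 2 (`NC1=NC2(CCOCC2)N(OCCCOc2ccc(Cl)cc2Cl)C(N)=N1`) gives 880 nM in this assay and so lies far higher, a gap well beyond the scatter. Among the measured compounds shown here, no pair of measured compounds isolates a single change, so the size of the next step has no direct measure.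

Compound 3 (`NC1=NC2(CCSCC2)N(OCCCOc2ccccc2Br)C(N)=N1`) carries 2-bromophenyl in place of 3,4-dichlorophenyl on an oxygen on a saturated carbon. The change is 2-bromophenyl in place of 3,4-dichlorophenyl on an oxygen on a saturated carbon and the rest of compound 1 stays as it is.

Since compound 1 at 1 nM sits at the bottom of the numbers seen, and compound 2 at 880 nM shows how far they can climb, a move upward beyond the scatter is expected in this assay for this swap. The expected step is a 40-fold higher number from compound 1 to compound 3 (1.60 log units; beyond the scatter) and it remains only an estimate. Compound 3 is estimated at 40 nM with an expected range of 4 nM to 400 nM for the measurement still to come.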

Compound 3, half-maximal inhibitory concentration: 1 nM
Estimate against measurement, compound 3: 40-fold (1.60 log units) above, and the stated range ends above it.
By their numbers in this assay, from the lowest: compounds 1 and 3 (each within the scatter of the next); then compound 2.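

In this assay the replacement of 3,4-dichlorophenyl by 2-bromophenyl on an oxygen on a saturated carbon brings no change at the digits printed from compound 1 to compound 3 (within the scatter) and gives the only measure so far of a single change in this series. It shows that, with the rest of compound 1 held fixed, this place tolerates a swap of two chlorine atoms for one bromine atom, and of eight heavy atoms for seven, without a change in the read-out beyond the scatter. The compounds shown offer no measured property or other evidence that would explain why these two groups give matching values.

Still open, from the compounds shown here alone, is whether this tolerance extends beyond halogenated phenyl groups, for instance to an unsubstituted phenyl, a methoxyphenyl, a phenyl carrying a carboxylic acid or an amine, or to a longer chain in this part of the molecule. Among these compounds, also open is how much of the wide gap in value between compound 1 and compound 2 belongs to each of the places in which they differ, since no single step connects those two compounds.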